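Alkyl in place of fluoro on the anilide ring

This account rests on a few compounds, and the source may have more. Where it says the series, first, only, none or still open, it means among the compounds named here.

Measured compounds:
compound 1, `O=C1NCCN1c1ccc(S(=O)(=O)Nc2ccc(F)cc2)cc1`: 370 nM in a functional assay on HT-29 cells (Homo sapiens) for antiproliferative activity, read by sulforhodamine B assay, with a stated time of 48 h; a higher number here means a weaker inhibitor, a lower number a stronger inhibitor
compound 2, `CC(C)(C)c1ccc(NS(=O)(=O)c2ccc(N3CCNC3=O)cc2)cc1`: a limit of this assay, > 1000 nM

For the measured compounds named here, compound 1 holds the only definite number in this assay; the other value shown is a limit. Going by the values given here, the single measured step runs an at least 2.7-fold higher number from compound 1 to compound 2 (0.43 log units; beyond the scatter), and it ends at the limit of > 1000 nM in this assay, at which 1 of the 2 values shown sits, so its true size is open upward.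

Compound 3, `CCc1cccc(NS(=O)(=O)c2ccc(N3CCNC3=O)cc2)c1`, differs from compound 1 by 3-ethylphenyl in place of 4-fluorophenyl on a sulfonamide nitrogen. The step from compound 1 to compound 2 bears on this change, since there too an alkyl group enters where fluoro stood, and the number rose at least modestly. The ethyl group is smaller than tert-butyl and sits in a different place on the ring, so the account does not carry the step over in full, yet it expects the number in this assay to rise beyond the scatter rather than to fall.

Compound 3 is therefore expected to give 800 nM, within 350 nM to 2000 nM, an expected step of a 2.2-fold higher number from compound 1 to compound 3 (0.33 log units; beyond the scatter), with a real chance that only a limit is reported.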

Compound 3, half-maximal inhibitory concentration: 110 nM
Estimate against measurement, compound 3: 7.3-fold (0.86 log units) above; the whole stated range lies above it.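

Replacing 4-fluorophenyl with 3-ethylphenyl on the sulfonamide nitrogen gives a 3.4-fold lower number from compound 1 to compound 3 (0.53 log units; beyond the scatter) in this assay, so a ring carrying an alkyl group at this position can go with a stronger inhibitor, not only a weaker one. The earlier step, an at least 2.7-fold higher number from compound 1 to compound 2 (0.43 log units; beyond the scatter), therefore does not describe alkyl-bearing rings here in general: compound 2 fits a rise in the number, while compound 3 goes against it. The value of compound 2 is a limit and not a number, so the distance between these two opposite outcomes has no fixed size: the limit of > 1000 nM in this assay, at which 1 of the 3 values shown sits.

Compound 3 differs from compound 1 in both the group on the ring and its place there, so the compounds shown cannot separate the contribution of the ethyl group from that of its position. They also leave open how 4-ethylphenyl, or a ring carrying methyl, propyl or methoxy in the position held by ethyl in compound 3, would read in this assay.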